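Working notes: a bromophenyl isomer in the sulfonamide series

The source may hold more compounds than are shown below. What is called first, only, known or untested is meant among the compounds shown, and "the series" means these compounds.

Among the compounds with values here, in a functional assay on HeLa cells (Homo sapiens) for cytotoxicity, read by sulforhodamine B assay (a higher number here means a weaker inhibitor, a lower number a stronger inhibitor), compound 1 `COc1ccc(S(=O)(=O)NC(C)C2=CC(=O)c3c(O)ccc(O)c3C2=O)c(OC)c1` gives 19500 nM, and compound 2 `CC(NS(=O)(=O)c1cccc(Br)c1)C1=CC(=O)c2c(O)ccc(O)c2C1=O` gives 6350 nM, the lower of the two numbers so far. Within the data shown here, the only measured step is a 3.1-fold lower number from compound 1 to compound 2 (0.49 log units; beyond the scatter), which is modest but beyond the scatter. It comes with 3-bromophenyl in place of 2,4-dimethoxyphenyl on a sulfonyl sulfur.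

Compound 3 `CC(NS(=O)(=O)c1ccccc1Br)C1=CC(=O)c2c(O)ccc(O)c2C1=O` is not yet measured. It keeps the shared core and carries 2-bromophenyl in place of 3-bromophenyl on a sulfonyl sulfur. Among the measured compounds shown here, no measured pair tests this kind of exchange, since a 3.1-fold lower number from compound 1 to compound 2 (0.49 log units; beyond the scatter) involves a different group and gives only a rough scale. A smaller change than that step is expected, with no direction favoured and nothing beyond the scatter. The expected step is a 1.1-fold higher number from compound 2 to compound 3 (0.04 log units; within the scatter). For compound 3 the estimated value is 7000 nM, within an expected range of 2800 nM to 16000 nM.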

Compound 3, half-maximal inhibitory concentration: 6200 nM
Estimate against measurement, compound 3: 1.1-fold (0.05 log units) above; the measured number falls inside the stated range.
By their numbers in this assay, from the lowest: compounds 3 and 2 (each within the scatter of the next); then compound 1.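

In this assay, 2-bromophenyl in place of 3-bromophenyl on a sulfonyl sulfur gives a 1.0-fold lower number from compound 2 to compound 3 (0.01 log units; within the scatter) and so separates nothing: at this position the two bromophenyl isomers cannot be told apart. Measured against 2,4-dimethoxyphenyl, the new isomer gives a 3.1-fold lower number from compound 1 to compound 3 (0.50 log units; beyond the scatter) and so matches the size of the step already seen with compound 2, which shows that the lower number does not depend on which of these two bromophenyl groups is present. No supporting evidence bears on why either step has the size it has.

Still open, on these data alone, is whether bromine matters at all, a question that a plain phenyl or a chlorophenyl on the same sulfur would address. Also open, as far as these compounds go, is how this position responds to a phenyl carrying an amine or a carboxylic acid.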